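Could a pyridine amide lower clearance of compound 3?

The compounds below may be only part of what the source reports. "The series", "measured", "known", "first", "only" and "open" are said of these compounds alone.

In an ADME assay on microsomes from liver (Homo sapiens) for metabolic stability, read by LC-MS, using NADPH, with stated times of 5 min and 30 min, tested at 1 uM (a lower number here means slower removal, a higher number faster removal of the compound), compound 3 `CN(c1ccn(C)n1)c1cnc(NCc2c(F)ccc3c2CCO3)n2cnnc12` gives 11 mL.min-1.g-1. Compound 1 `Fc1ccc2c(c1CNc1ncc(Oc3ccccc3)c3nncn13)CCO2` gives 18 mL.min-1.g-1. The gap between these two is a 1.6-fold lower number from compound 1 to compound 3 (0.21 log units; within the scatter), so they cannot be told apart. Compound 2 `COCCC(=O)Nc1cnc(NCc2c(F)ccc3c2CCO3)n2cnnc12` gives < 3 mL.min-1.g-1, which is a limit of the assay and not a measured number.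

Compound 4 `O=C(Nc1cnc(NCc2c(F)ccc3c2CCO3)n2cnnc12)c1cccnc1` has not yet been measured. It keeps the shared core and changes one group: ((pyridin-3-yl)carbonyl)amino in place of methyl(1-methyl-1H-pyrazol-3-yl)amino on an aromatic carbon. The entering ((pyridin-3-yl)carbonyl)amino carries a carbonyl on an amino link, as does the ((2-methoxyethyl)carbonyl)amino of compound 2. That makes compound 2 the closest guide. Going by the values given here, two measured steps bear on the question: an at least 6.0-fold lower number from compound 1 to compound 2 (0.77 log units; beyond the scatter) and an at least 3.6-fold higher number from compound 2 to compound 3 (0.56 log units; beyond the scatter). Both lie beyond the scatter, and in both the compound carrying the carbonyl group has the lower number. Among the compounds with values here, compound 2 is the only measured compound of this kind, however, and its side chain ends differently from the pyridine ring of compound 4. A lower number is therefore expected in this assay, but the step may be small. The expected change is a 2.2-fold lower number from compound 3 to compound 4 (0.34 log units; beyond the scatter). For compound 4 the estimated value is 5 mL.min-1.g-1, with an expected range from 2 mL.min-1.g-1 to 12 mL.min-1.g-1.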

Compound 4, intrinsic clearance in microsomes: < 3 mL.min-1.g-1
Compound 4 was reported as a limit (the forecaster's own chance of this, stated with the estimate: 30%); middle value at least 1.6-fold (0.22 log units) from the limit.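

In this assay, putting ((pyridin-3-yl)carbonyl)amino in place of methyl(1-methyl-1H-pyrazol-3-yl)amino gives an at least 3.6-fold lower number from compound 3 to compound 4 (0.56 log units; beyond the scatter), and putting the same group in place of phenoxy gives an at least 6.0-fold lower number from compound 1 to compound 4 (0.77 log units; beyond the scatter). Compound 4 is reported as < 3 mL.min-1.g-1, which is a limit of the assay and not a number. Compound 2 was the only earlier compound with a carbonyl on an amino link at this aromatic carbon, and compound 4 shows that the low reading is not tied to its 2-methoxyethyl chain, since it also appears with pyridin-3-yl on the carbonyl carbon, although the step between these two amides cannot be read: the limit of < 3 mL.min-1.g-1 in this assay, at which 2 of the 4 values shown sit.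

The compounds shown leave open how far the group on the carbonyl carbon can change before a measurable number returns, for example with a morpholine, a carboxylic acid or a longer alkyl chain in that place. They also leave open whether the amide hydrogen matters, a question that a methyl group on the amide nitrogen would address.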